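Benzoyl to Triazolylcarbonyl: Predicting Compound 4

The source may hold more compounds than are shown below. What is called first, only, known or untested is meant among the compounds shown, and "the series" means these compounds.

Measured in an ADME assay on microsomes (Rattus norvegicus) for metabolic stability; on this read-out lower numbers stand for a shorter-lived compound and higher numbers for a longer-lived compound:
compound 1 `O=C(c1ccccc1)N1CCC(C(=O)N2N=CCC2c2ccccc2)CC1` gives 0.0833 h
compound 2 `O=C(C1CCCC1)N1N=CCC1c1ccccc1` gives 0.2 h
compound 3 `CC(C)(C)C(=O)N1N=CCC1c1ccc(Cl)cc1` gives 0.145 h

Compound 1 has the lowest of the three numbers in this assay. Its nearest neighbour is compound 3, whose value lies within the scatter of that of compound 1, so the two cannot be told apart. Within the data shown here, compound 2 stands furthest away, beyond the scatter, and is the only compound here clearly longer-lived than compound 1.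

The unmeasured compound 4 `O=C(c1c[nH]nn1)N1CCC(C(=O)N2N=CCC2c2ccccc2)CC1` is derived from compound 1 by one change: 1H-1,2,3-triazol-4-yl in place of phenyl on a carbonyl carbon. Among the measured compounds shown here, no pair of measured compounds shows a comparable exchange, so there is no measured step to lean on; the three measured compounds differ in several places at once.

With nothing directly comparable, the author expects the step of a 1.3-fold higher number from compound 1 to compound 4 (0.12 log units; within the scatter) in this assay to be small and upward, probably not beyond the scatter. For compound 4 the estimate in this assay is 0.11 h, with a plausible range from 0.05 h to 0.25 h.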

Compound 4, half-life: > 2.75 h
Compound 4: no number, only a limit; the forecaster's own chance of this, stated with the estimate: 5%; middle value at least 25-fold (1.39 log units) from the limit.
By their numbers in this assay, from the lowest: compounds 1, 3 and 2 (each within the scatter of the next, the first and the last beyond it). At a limit, above all of these: compound 4.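

On a carbonyl carbon whose other neighbour is an amide-type nitrogen in a ring, 1H-1,2,3-triazol-4-yl in place of phenyl gives an at least 33-fold higher number from compound 1 to compound 4 (1.51 log units; beyond the scatter) in this assay. Compound 4 gives > 2.75 h, which is a limit of the assay and not a number: the limit of > 2.75 h in this assay, at which 1 of the 4 values shown sits. Among these compounds, the three earlier compounds differ in several places at once and offered no single-place step, whereas here one exchange alone carries the whole difference.

The entering ring differs from phenyl in ring size, in its nitrogen atoms and in its hydrogen-bond donor all at once, and the compounds shown do not separate these. From the compounds shown here alone, whether a pyridine ring or a methylated triazole on the same carbonyl carbon would give a comparable half-life stays open.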